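From Compound 2 to Compound 4: Adding a Methoxy

The source may hold more compounds than are shown below. What is called first, only, known or untested is meant among the compounds shown, and "the series" means these compounds.

In a functional assay on A549 cells (Homo sapiens) for cytotoxicity, read by WST assay, with a stated time of 24 h (on this read-out higher numbers stand for weaker inhibition and lower numbers for stronger inhibition), compound 1 `N#C/C(=C\c1c[nH]c2cc(F)ccc12)C(=O)c1c[nH]c2cc(F)ccc12` gives only a limit, > 50000 nM. Compound 2 `N#C/C(=C\c1c[nH]c2cc(F)ccc12)C(=O)c1c[nH]c2ccccc12` gives 17000 nM, and compound 3 `COc1ccc2c(/C=C(\C#N)C(=O)c3c[nH]c4ccccc34)c[nH]c2c1` gives 9600 nM. Going by the values given here, compound 2 thus stands within the scatter of compound 3, the only other numerical value, as the step of a 1.8-fold lower number from compound 2 to compound 3 (0.25 log units; within the scatter) shows. Compound 4 `COc1ccc2[nH]cc(C(=O)/C(C#N)=C/c3c[nH]c4cc(F)ccc34)c2c1` is not yet measured. It differs from compound 2 by methoxy in place of hydrogen on an aromatic carbon, which is methoxy in place of hydrogen on an aromatic carbon.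

Among the compounds with values here, two measured steps bear on this change. The closer one is an at least 2.9-fold lower number from compound 1 to compound 2 (0.46 log units; beyond the scatter), which also sets a substituent against hydrogen in the same part of the structure. Read in reverse, it links the added group to a higher number. This step starts from a limit. Its full size is not known. The other step, a 1.8-fold lower number from compound 2 to compound 3 (0.25 log units; within the scatter), swaps methoxy for fluoro elsewhere in the structure. A small upward move is therefore expected, and the expected step is a 1.5-fold higher number from compound 2 to compound 4 (0.17 log units; within the scatter). Compound 4 is estimated at 25000 nM, with an expected range of 8000 nM to 50000 nM.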

Compound 4, half-maximal inhibitory concentration: > 50000 nM
Compound 4: no number, only a limit (the forecaster's own chance of this, stated with the estimate: 30%); middle value at least 2.0-fold (0.30 log units) from the limit.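

In this assay, methoxy in place of hydrogen on this aromatic carbon, meta to a fused ring and para to a fused ring, gives an at least 2.9-fold higher number from compound 2 to compound 4 (0.46 log units; beyond the scatter). Going by these compounds alone, this is the first direct comparison of methoxy with hydrogen at this place, since the only earlier methoxy, in compound 3, replaced fluoro elsewhere in the structure and its step from compound 2 stayed within the scatter. The full size of the new step is not known, since compound 4 gives only a limit and not a number, like one other compound shown: the limit of > 50000 nM in this assay, at which 2 of the 4 values shown sit.

The compounds shown leave open how far the number for compound 4 lies past that limit. They also leave open what an amine, a carboxylic acid or a longer chain such as ethoxy on this same carbon would give.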